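Notes on the series: from compound 2 to compound 3

The source may hold more compounds than are shown below. What is called first, only, known or untested is meant among the compounds shown, and "the series" means these compounds.

In a functional assay on the whole organism (strain Kunming) with Mus musculus as the target, in the formalin test, with a stated time of 0.5 h (a lower number here means that less compound is needed, a higher number that more compound is needed for the effect), compound 1 (`COc1cc(OC)c(OC)cc1/C=C/COC(=O)/C=C/c1ccc(OC)c(OC)c1`) gives 93.3 mg/kg and compound 2 (`COc1cc(OC)c(OC)cc1/C=C/COC(=O)/C=C/c1ccccc1Cl`) gives 101 mg/kg. These two numbers lie within the scatter of each other, so compound 2 stands level with compound 1 and the pair shows no separation.

The move to compound 3 (`COc1cccc(/C=C/C(=O)OC/C=C/c2cc(OC)c(OC)cc2OC)c1`) puts 3-methoxyphenyl in place of 2-chlorophenyl on a double-bonded chain carbon bound to a double-bonded chain carbon. Among the measured compounds shown here, only one measured step bears on this exchange, as it falls at the same place: 2-chlorophenyl in place of 3,4-dimethoxyphenyl (a 1.1-fold higher number from compound 1 to compound 2 (0.03 log units; within the scatter)). That step stays within the scatter, so exchanging these groups has not yet moved the number in this assay. For the measured compounds named here, one step is thin evidence, and no measured compound carries 3-methoxyphenyl.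

No direction can be assigned, and the expected step is no larger than the scatter (a 1.0-fold lower number from compound 2 to compound 3 (0.02 log units; within the scatter)). The expected value for compound 3 is 97 mg/kg within an estimated range of 52 mg/kg to 180 mg/kg for this measurement.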

Compound 3, dose for half-maximal effect: > 100 mg/kg
Compound 3 was reported as a limit; the forecaster's own chance of this, stated with the estimate: 5%; at least 1.0-fold (0.01 log units) between middle value and limit.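

In this assay compound 3 gives > 100 mg/kg, which is a limit of the assay and not a number. Hydrogen in place of methoxy on an aromatic carbon gives an at least 1.0-fold higher number from compound 1 to compound 3 (0.03 log units; that floor lies within the scatter), so this change has only a floor; the floor shows no separation, and a larger true step remains possible. The step involving the exchange of 2-chlorophenyl for 3-methoxyphenyl cannot be read, because one side of it is a limit, so this position still has no readable step beyond the scatter: the limit of > 100 mg/kg in this assay, at which 1 of the 3 values shown sits.

Left open is where compound 3 would fall if it gave a number, and with it whether 3-methoxyphenyl separates from 2-chlorophenyl or from the 3,4-dimethoxyphenyl of compound 1. Also open, going by these compounds, is whether an aromatic ring bearing an amine or a carboxylic acid at this position on a double-bonded chain carbon bound to a double-bonded chain carbon, or a longer chain in that part of the shared core, would give a step beyond the scatter in this assay.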